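Switching the aryl ether on the triazole arm of compound 3

The source may hold more compounds than are shown below. What is called first, only, known or untested is meant among the compounds shown, and "the series" means these compounds.

Measured so far in a functional assay on SW480 cells (Homo sapiens) for antiproliferative activity, read by MTT assay, with a stated time of 48 h; on this read-out higher numbers stand for weaker inhibition and lower numbers for stronger inhibition:
compound 1, `O=c1cc(-n2cc(CNc3ccccc3)nn2)c2cc(Br)ccc2o1` — 18400 nM
compound 2, `O=c1cc(-n2cc(CSc3ccccc3)nn2)c2cc(Br)ccc2o1` — 15400 nM
compound 3, `O=c1cc(-n2cc(COc3cccnc3)nn2)c2cc(Br)ccc2o1` — 39800 nM

Compound 3 gives the highest number of the three; the steps of a 2.2-fold higher number from compound 1 to compound 3 (0.34 log units; beyond the scatter) and a 2.6-fold higher number from compound 2 to compound 3 (0.41 log units; beyond the scatter) both run beyond the scatter, whereas a 1.2-fold lower number from compound 1 to compound 2 (0.08 log units; within the scatter) does not. Compound 4, `O=c1cc(-n2cc(COc3ccccc3O)nn2)c2cc(Br)ccc2o1`, differs from compound 3 by 2-hydroxyphenyl in place of pyridin-3-yl on an oxygen on a saturated carbon. Among the compounds with values here, no measured step changes only this aryl group: the two steps that reach compound 3 exchange both the linking atom and the ring at once, so they bear on the change only loosely. They show that an anilino or phenylsulfanyl arm gives modestly lower numbers than the (pyridin-3-yl)oxy arm, and that two different arms carrying a carbon-only ring sit within the scatter of each other. On that basis compound 4 is expected to move toward those compounds by a modest margin, a 1.6-fold lower number from compound 3 to compound 4 (0.20 log units; within the scatter), with an outcome within the scatter remaining quite possible. The estimate for compound 4 is 25000 nM, with a range from 10000 nM to 60000 nM.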

Compound 4, half-maximal inhibitory concentration: 19100 nM
For compound 4 the middle estimate is 1.3-fold (0.12 log units) above the measured one; low and high end bracket the measured number.
By their numbers in this assay, from the lowest: compounds 2, 1 and 4 (each within the scatter of the next); then compound 3.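

In this assay the change of 2-hydroxyphenyl in place of pyridin-3-yl on an oxygen on a saturated carbon, with the linking atom held constant, gives a 2.1-fold lower number from compound 3 to compound 4 (0.32 log units; beyond the scatter) and so lies modestly beyond the scatter. The 2-hydroxyphenoxy arm also sits within the scatter of the other two arms, with a 1.2-fold higher number from compound 2 to compound 4 (0.09 log units; within the scatter) and a 1.0-fold higher number from compound 1 to compound 4 (0.02 log units; within the scatter) both small. Among the four compounds, only compound 3, whose ring carries a hetero atom, stands apart from the others.

The compounds shown leave open whether the step follows the loss of the ring nitrogen or the arrival of the hydroxyl, and a plain phenyl on this oxygen would separate the two. No measurement given here bears on why this exchange shifts the number.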